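The source may report more compounds than this note shows. Statements on the series, on what has been measured and on what is new or still open speak of the compounds shown alone.

Measured compounds: compound 1 `O=C(O)c1ccc(C(=O)c2ccc(C(=O)c3ccc(O)cc3)cc2)cc1` gives 22 nM in an assay on CHO cells for inhibition of 3-oxo-5-alpha-steroid 4-dehydrogenase 2 (Homo sapiens); a lower number here means a stronger inhibitor, a higher number a weaker inhibitor; compound 2 `O=C(O)c1ccc(C(=O)c2ccc(C(=O)c3ccc(C(F)(F)F)cc3)cc2)cc1` gives 30 nM; compound 3 `O=C(O)c1ccc(C(=O)c2ccc(-c3ccc(Cl)cc3Cl)cc2)cc1` gives 85 nM.

Among these three numbers compound 1 holds the lowest value. For the measured compounds named here, compound 2 comes nearest, and the only step that differs in one place, a 1.4-fold higher number from compound 1 to compound 2 (0.13 log units; within the scatter), lies within the scatter. Going by the values given here, compound 3 stands furthest from compound 1, and its value against 22 nM for compound 1 shows a gap beyond the scatter, though the two structures differ in more than one place and no single step between them is defined.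

Compound 4 `O=C(O)c1ccc(C(=O)c2ccc(C(=O)c3ccc(Cl)c(Cl)c3)cc2)cc1` has not yet been measured. Its change from compound 1 is 3,4-dichlorophenyl in place of 4-hydroxyphenyl on a carbonyl carbon. Among the compounds with values here, the one step that bears on it, a 1.4-fold higher number from compound 1 to compound 2 (0.13 log units; within the scatter), shows that exchanging the hydroxy on that ring cost little. The dichlorophenyl of compound 4 is a larger change, and compound 3 with its dichlorophenyl shows a higher value, so a modest rise is expected for compound 4, of the size a 1.8-fold higher number from compound 1 to compound 4 (0.26 log units; within the scatter). The estimate for compound 4 is 40 nM, expected between 15 nM and 110 nM.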

Compound 4, inhibition constant: 35 nM
For compound 4 the middle estimate is 1.1-fold (0.06 log units) above the measured one; the measured number falls inside the stated range.
By their numbers in this assay, from the lowest: compounds 1, 2 and 4 (each within the scatter of the next); then compound 3.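

In this assay, the exchange on the carbonyl carbon gives a 1.6-fold higher number from compound 1 to compound 4 (0.20 log units; within the scatter), so replacing the whole 4-hydroxyphenyl leaves the number as unchanged as the earlier exchange of the hydroxy alone did. The entering 3,4-dichlorophenyl has 0 hydrogen-bond donors and 0 hydrogen-bond acceptors, against 1 of each in the group that leaves, and this position still shows no change beyond the scatter. No measurement shown here explains this tolerance.

The compounds shown leave open whether the position also accepts an amine or a carboxylic acid on this ring, or a cyclohexyl group in place of the ring. They also leave open what the carbonyl itself contributes, since compound 3 differs from compound 1 in more than one place.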